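Ring methyl on the carboxyphenyl side: compound 4

The compounds below may be only part of what the source reports. "The series", "measured", "known", "first", "only" and "open" are said of these compounds alone.

Measured so far in an ADME assay (liver) for metabolic stability, with Liver microsome (Rattus norvegicus) as the target, read by LC-MS, using microsomes and NADPH, with stated times of 5 min and 60 min, tested at 4 uM; a higher number here means that more of the compound is left, a lower number that less of the compound is left:
- compound 1, `Cc1c(OCCCCOc2cccc(C(=O)O)c2)ccc(C(=O)CC(C)C)c1C`: 29%
- compound 2, `Cc1c(OCCCCOc2cccc(C(=O)O)c2)ccc(C(=O)CC(C)C)c1O`: 51%
- compound 3, `Cc1c(OCCCCOc2cccc(C(=O)O)c2)ccc(C(=O)CC2CCCC2)c1O`: 55%

Compound 2 stands second highest of the three numbers. Its nearest neighbour is compound 3, reached by a number 4 percentage points higher from compound 2 to compound 3 (within the scatter), a step within the scatter. Compound 1 lies furthest away: a number 22 percentage points higher from compound 1 to compound 2 (beyond the scatter).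

Compound 4, `Cc1ccc(C(=O)O)cc1OCCCCOc1ccc(C(=O)CC(C)C)c(O)c1C`, differs from compound 2 by methyl in place of hydrogen on an aromatic carbon; cut one bond further out, the change reads 3-carboxyphenyl to 5-carboxy-2-methylphenyl.

Neither measured step touches this ring. The step from compound 1 to compound 2 concerns the other aromatic ring and a different exchange; the step from compound 2 to compound 3 concerns the chain at the carbonyl and stayed within the scatter. Among the measured compounds shown here, with no step bearing directly on a methyl entering this position, no change beyond the scatter is expected in this assay, and the value of compound 2 is taken as the anchor.

For compound 4 the estimate is 52%, expected to fall between 35% and 68%. This estimate corresponds to an expected step of a number 1 percentage points higher from compound 2 to compound 4 (within the scatter).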

Compound 4, percent of the compound remaining: 21%
Compound 4: middle estimate off by 31 percentage points, on the high side; measured number outside the range, below it.
By their numbers in this assay, from the lowest: compounds 4 and 1 (each within the scatter of the next); then compounds 2 and 3 (each within the scatter of the next).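

A single methyl in place of hydrogen on the carboxyphenyl ring, ortho to a large group and para to a carboxy group, is enough to shift the result in this assay, with a number 30 percentage points lower from compound 2 to compound 4 (beyond the scatter) as the step. Among the compounds shown here, the earlier steps touched only the other aromatic ring and the chain at the carbonyl, so this is the first sign that the carboxyphenyl ring is not a silent part of the molecule in this read-out. Nothing on hand accounts for this loss of remaining compound.

From the compounds shown here alone, it remains open whether the loss is particular to methyl or would also follow with fluorine, methoxy or a longer alkyl chain on this carbon. Also open, going by these compounds, is whether the same methyl would give a similar step on compound 3, with its cyclopentyl group.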